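The compounds below may be only part of what the source reports. "The series", "measured", "known", "first", "only" and "open" are said of these compounds alone.

Compound 1 `O=C(CCCCC1CCSS1)Nc1ccc([N+](=O)[O-])c(C(F)(F)F)c1` carries a ring at the end of its chain. In a functional assay on NCI-H460 cells (Homo sapiens) for inhibition, read by MTT assay, with a stated time of 24 h, tested at 100 ug/mL (a higher number here means more inhibition of growth at the concentration tested, a lower number less inhibition of growth), compound 1 gives 51.7%. Compound 3 `O=C(CCCCC(S)CCS)Nc1ccc([N+](=O)[O-])c(C(F)(F)F)c1` has the same shared core but an open chain in place of that ring: the change is a group of 5 heavy atoms (3 carbon, 2 sulfur; no ring) in place of a group of 5 heavy atoms (3 carbon, 2 sulfur; one five-membered non-aromatic ring with 2 hetero atoms), on a saturated chain carbon, four bonds along the chain from a carbonyl carbon. In this assay compound 3 gives 95.9%. This step, a number 44.2 percentage points higher from compound 1 to compound 3 (beyond the scatter), is the only one of its kind measured here. Compound 2 `O=C(CCCCC1CCSS1)Nc1cccc2ccccc12` keeps the ring-bearing chain of compound 1 on a different core; the difference between the two cores is not broken down here. In this assay compound 2 is reported as "not active" (no number reported). Compound 4 `O=C(CCCCC(S)CCS)Nc1cccc2ccccc12` makes the same change on the core of compound 2: a group of 5 heavy atoms (3 carbon, 2 sulfur; no ring) in place of a group of 5 heavy atoms (3 carbon, 2 sulfur; one five-membered non-aromatic ring with 2 hetero atoms), on a saturated chain carbon, four bonds along the chain from a carbonyl carbon. Because the step from compound 1 to compound 3 was a number 44.2 percentage points higher from compound 1 to compound 3 (beyond the scatter), a step of the same kind is expected here, though compound 2 starts from no reported number, so the size is uncertain. Compound 4 is therefore expected to show around 40% in this assay, estimated between 5% and 80%.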

Compound 4, percent growth inhibition at one concentration: 2.18%
The estimate for compound 4 lay 37.8 percentage points above the measured number; measured number below the stated range.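

Within the data shown here, compound 2 is reported in this assay only as "not active", without a number, so no step from it to compound 4 can be read. The compounds shown leave open whether opening the ring changes growth inhibition on this core as it does on the core of compound 1. Nothing measured here bears on the reason for this result.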